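The source may report more compounds than this note shows. Statements on the series, on what has been measured and on what is new or still open speak of the compounds shown alone.

Measured so far:
Compound 1 `CN(Cc1ccc(OCCCNC(=N)N)cc1)c1nc2ccc(Oc3ccc(C(F)(F)F)cc3)cc2s1`: 185000 nM
Compound 2 `CN(Cc1ccc(OCCCN)cc1)c1nc2ccc(Oc3ccc(C(F)(F)F)cc3)cc2s1`: 283000 nM

In an assay on SH-SY5Y cells for inhibition of Voltage-dependent N-type calcium channel subunit alpha-1B (Homo sapiens), read by FLIPR and calcium flux, with stated times of 600 s and 300 s, in the presence of a further agent that is not named here (on this read-out higher numbers stand for weaker inhibition and lower numbers for stronger inhibition), compound 1 gives 185000 nM, the lower of the two numbers recorded, and compound 2 gives 283000 nM. Within the data shown here, the only measured step, a 1.5-fold higher number from compound 1 to compound 2 (0.18 log units; within the scatter), concerns the amine end of the molecule and stays within the scatter, so the two compounds cannot be told apart on this read-out.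

Compound 3 `CN(Cc1ccc(OCCCNC(=N)N)cc1)c1nc2ccc(Oc3ccc(F)cc3)cc2s1` keeps the amine end of compound 1 and changes the far end instead: fluoro in place of trifluoromethyl on an aromatic carbon, on an aromatic carbon of a six-membered aromatic ring of carbon only. Among the measured compounds shown here, no measured pair touches that part of the structure, so the step from compound 1 to compound 2 says nothing about what this exchange does. Lacking any direct comparison, the expectation for compound 3 is a number close to that of compound 1, with the step of a 1.3-fold higher number from compound 1 to compound 3 (0.11 log units; within the scatter) expected to stay within the scatter but with a wide range. Compound 3 is therefore estimated at 240000 nM, between 90000 nM and 650000 nM.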

Compound 3, half-maximal inhibitory concentration: 100000 nM
For compound 3 the middle estimate is 2.4-fold (0.38 log units) above the measured one; the range from low to high includes it.
By their numbers in this assay, from the lowest: compounds 3, 1 and 2 (each within the scatter of the next, the first and the last beyond it).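

In this assay, among these compounds, the exchange of 4-(trifluoromethyl)phenoxy for 4-fluorophenoxy (a 1.9-fold lower number from compound 1 to compound 3 (0.27 log units; within the scatter)) gives the first measured look at this end of the molecule. On this aromatic carbon, para to a large group, a much smaller fluoro takes the place of trifluoromethyl without a difference that can be separated from the ordinary variation between repeated measurements, so this pair shows no sign that the read-out depends on which of these two groups is present. Nothing measured here offers an explanation for this result.

From the compounds shown here alone, with only these two groups compared at this carbon, it remains open whether a plain hydrogen, a chloro, a methoxy or a nitrile there would give a number clearly apart from those of compound 1 and compound 3. Also open, going by these compounds, is whether fluoro would give a similar result in compound 2, which carries the amine end, and whether a longer chain at that end would shift the number beyond the scatter.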